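A few compounds are considered here, and "the series" means these few. Any claim that something is new, unique, unknown or untested is made for them only; others in the source may bear on it.

Series notes, cytotoxicity arm. In an ADME assay on HEK293 cells (Homo sapiens) for cytotoxicity, read by sulforhodamine B assay, with a stated time of 48 h, tested at 10 uM (on this read-out higher numbers stand for more inhibition at the one concentration tested (going by the name of the read-out) and lower numbers for less inhibition), compound 1 `CCCCCCc1cn(C(c2ccccc2)c2cc3cc(Br)ccc3nc2OC)nn1` gives -3.17%, the lowest of the three numbers in hand. Its nearest neighbour is compound 2 `CCCCCc1cn(C(c2ccccc2)c2cc3cc(Br)ccc3nc2OC)nn1`, which in this assay gives -2%; the change is a number 1.2 percentage points higher from compound 1 to compound 2 (within the scatter). The furthest is compound 3 `COc1nc2ccc(Br)cc2cc1C(c1ccccc1)n1cc(-c2cccc(F)c2)nn1`, which in this assay gives 6.84%; the change is a number 10 percentage points higher from compound 1 to compound 3 (within the scatter). Between compound 2 and compound 3 the change is a number 8.8 percentage points higher from compound 2 to compound 3 (within the scatter). None of the three compounds therefore separates from the others, and the whole set sits near the no-inhibition mark at the single concentration tested.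

Compound 4 `COc1nc2ccc(Br)cc2cc1C(c1ccccc1)n1cc(C2CC2)nn1` is not yet measured. It differs from compound 1 as follows: cyclopropyl in place of hexyl on an aromatic carbon. The measured steps that bear on it are those that swap the hexyl of compound 1 for another group on the same aromatic carbon, a number 10 percentage points higher from compound 1 to compound 3 (within the scatter), and the chain shortening a number 1.2 percentage points higher from compound 1 to compound 2 (within the scatter); both lie within the scatter. No step beyond the scatter is therefore expected in this assay, in either direction. The estimate for compound 4 in this assay is 0%, within -10% to 10%, which means a step of a number 3.2 percentage points higher from compound 1 to compound 4 (within the scatter).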

Compound 4, a percentage reported as inhibition, at one concentration (the size of the read-out at that concentration, not a potency): 8.22%
Compound 4: middle estimate off by 8.2 percentage points, on the low side, and the stated range covers the measured number.
By their numbers in this assay, from the lowest: compounds 1, 2, 3 and 4 (each within the scatter of the next, the first and the last beyond it).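

In this assay this aromatic carbon of the five-membered ring gives its first steps beyond the scatter, with cyclopropyl in place of hexyl, a number 11.4 percentage points higher from compound 1 to compound 4 (beyond the scatter) and, with cyclopropyl in place of pentyl, a number 10.2 percentage points higher from compound 2 to compound 4 (beyond the scatter) in the same assay. A ring on this carbon does not separate from the chains in every case: 3-fluorophenyl in place of hexyl gives a number 10 percentage points higher from compound 1 to compound 3 (within the scatter) as a step, yet cyclopropyl and 3-fluorophenyl cannot be told apart, with a number 1.4 percentage points higher from compound 3 to compound 4 (within the scatter) as their step. No evidence at hand accounts for the separation of cyclopropyl from the two chains.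

Open, on these data alone, is whether a short chain such as ethyl, a larger ring such as cyclobutyl, or an amine on the same aromatic carbon would sit with cyclopropyl or with hexyl in this assay. As far as these compounds go, all four compounds share the rest of the core, so what a change elsewhere would do, such as a carboxylic acid in place of the bromine, also remains open.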